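Swapping the Aryl Group on a Triazole Nitrogen

A few compounds are considered here, and "the series" means these few. Any claim that something is new, unique, unknown or untested is made for them only; others in the source may bear on it.

This set of compounds was tested in an ADME assay on L02 cells (Homo sapiens) for antiproliferative activity, read by MTT assay, with a stated time of 48 h; on this read-out lower numbers stand for stronger inhibition and higher numbers for weaker inhibition. Compound 1 `N#CC1=C(N)Oc2c(c3nc4ccccc4nc3c3ccccc23)C12C(=O)N(Cc1cnnn1-c1ccc(Cl)cc1)c1ccccc12` returned only a limit of the assay, > 50000 nM. Compound 2 `Cc1ccc(-n2nncc2CN2C(=O)C3(C(C#N)=C(N)Oc4c3c3nc5ccccc5nc3c3ccccc43)c3ccccc32)cc1Cl`, which carries 3-chloro-4-methylphenyl in place of 4-chlorophenyl on an aromatic nitrogen, likewise returned only a limit, > 50000 nM. The step between them, a step that the two limits leave unreadable from compound 1 to compound 2, therefore cannot be read. Compound 3 `N#CC1=C(N)Oc2c(N)cc3nc4ccccc4nc3c2C12C(=O)N(Cc1cnnn1-c1ccc(Cl)cc1)c1ccccc12` also gave only a limit, > 50000 nM. All three values sit at the limit of > 50000 nM in this assay, at which 3 of the 3 values shown sit, so compound 3 stands level with its two companions and none of the three can be set apart from the others.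

Compound 4 `Cc1ccc(C)c(-n2nncc2CN2C(=O)C3(C(C#N)=C(N)Oc4c(N)cc5nc6ccccc6nc5c43)c3ccccc32)c1` differs from compound 3 in one place: 2,5-dimethylphenyl in place of 4-chlorophenyl on an aromatic nitrogen. Among the measured compounds shown here, the only measured step that resembles this change, an exchange of one aryl group for another on the same aromatic nitrogen, is the step from compound 1 to compound 2, and its size is not readable. For the measured compounds named here, there is thus no measured step that points to a shift beyond the usual scatter in either direction. For compound 4 the expectation is that this assay again reports a limit rather than a number, so that the estimated step that the limit leaves unreadable from compound 3 to compound 4 is expected to mean no readable change. The estimate for compound 4 is 80000 nM, with an expected range from 30000 nM to 300000 nM.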

Compound 4, half-maximal inhibitory concentration: > 50000 nM
Compound 4 gave a limit, no number; the forecaster's own chance of this, stated with the estimate: 85%; the middle value lies beyond the limit too.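

Compound 3 and compound 4 each gave only a limit in this assay, so the step between them cannot be read, and all the compounds shown stand at the same point: the limit of > 50000 nM in this assay, at which 4 of the 4 values shown sit.

The compounds shown leave open whether any aryl group on this aromatic nitrogen, or any other change to the shared core, would give a real number in this assay.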